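Sulfonyl-for-carbamate exchange on the two amine-bearing cores

This account rests on a few compounds, and the source may have more. Where it says the series, first, only, none or still open, it means among the compounds named here.

Measured so far, in an assay for inhibition of apolipoprotein B-100 (Homo sapiens), tested at 100 nM; on this read-out lower numbers stand for stronger inhibition and higher numbers for weaker inhibition:
compound 1 `COC(=O)NCC1Cc2ccc(NC(=O)c3cccc(C)c3-c3ccc(C(F)(F)F)cc3)cc2C1` gives 4.1 nM
compound 2 `Cc1cccc(C(=O)Nc2ccc3c(c2)CC(CNS(=O)(=O)c2cccs2)C3)c1-c1ccc(C(F)(F)F)cc1` gives 1.9 nM
compound 3 `COC(=O)NC1CCc2ccc(NC(=O)c3cccc(C)c3-c3ccc(C(F)(F)F)cc3)cc2CC1` gives 1.6 nM

Compound 2 and compound 3 lie within the scatter of each other in this assay; compound 1 sits beyond the scatter from both. For the measured compounds named here, the one step that can be counted is from compound 1 to compound 2, ((thiophen-2-yl)sulfonyl in place of methoxycarbonyl on an amine nitrogen), which gave a 2.2-fold lower number from compound 1 to compound 2 (0.33 log units; beyond the scatter).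

Compound 4 `Cc1cccc(C(=O)Nc2ccc3c(c2)CCC(NS(=O)(=O)c2cccs2)CC3)c1-c1ccc(C(F)(F)F)cc1` is not yet measured. It carries the same kind of change relative to compound 3, ((thiophen-2-yl)sulfonyl in place of methoxycarbonyl on an amine nitrogen), but the surroundings are not identical: in the change from compound 1 to compound 2 the amine nitrogen sits on a saturated chain carbon, whereas in compound 3 and compound 4 it sits on a saturated ring carbon. The difference between the core of compound 1 and the core of compound 3 is not broken down here.

Taking the only counted precedent as a guide, compound 4 is expected to move by a 2.0-fold lower number from compound 3 to compound 4 (0.30 log units; within the scatter) in this assay, because compound 2 showed a 2.2-fold lower number from compound 1 to compound 2 (0.33 log units; beyond the scatter) from compound 1. The estimate for compound 4 in this assay is 0.8 nM, with a range from 0.35 nM to 2 nM; the two cores are not directly comparable, so the spread is kept wide.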

Compound 4, half-maximal inhibitory concentration: 1.6 nM
For compound 4 the middle estimate is 2.0-fold (0.30 log units) below the measured one; the measured number falls inside the stated range.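

With an amine nitrogen on a saturated ring carbon, (thiophen-2-yl)sulfonyl in place of methoxycarbonyl gave no change at the digits printed from compound 3 to compound 4 (within the scatter) in this assay. For the compounds shown here, with only one pair on each core, this shows that the exchange can be carried to the second core without a weaker number, but it does not show that the size of the step carries over, nor that it depends on the core. The two steps themselves cannot be told apart: the same change on two cores in this assay, a 2.2-fold lower number (0.33 log units; beyond the scatter) from compound 1 to compound 2 and no change at the digits printed (within the scatter) from compound 3 to compound 4, 2.2-fold (0.33 log units) apart, within the scatter of two such steps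

The compounds shown leave open how a methanesulfonyl or a benzoyl group on the same amine nitrogen would read on either core, and so whether the thiophene ring or the sulfonyl part goes with the step seen on the core of compound 1. Going by these compounds alone, the effect of the core itself also stays unsplit: compound 1 and compound 3 differ in more than one place, and no step between them can be read.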